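Alkyl Chain Variants on a Shared Core Against ALOX12

The source may hold more compounds than are shown below. What is called first, only, known or untested is meant among the compounds shown, and "the series" means these compounds.

Compound 1, `CC(C)Cc1oc2ccccc2c(=O)c1O`, gives > 100000 nM.
Compound 2, `CC(C)(C)c1oc2ccccc2c(=O)c1O`, gives > 100000 nM.

Both were tested in an assay on isolated protein for inhibition of Polyunsaturated fatty acid lipoxygenase ALOX12 (Homo sapiens); a higher number here means a weaker inhibitor, a lower number a stronger inhibitor. For compound 1 the value > 100000 nM is a limit of the assay, not a number. For compound 2 the value > 100000 nM is likewise a limit. The step that the two limits leave unreadable from compound 1 to compound 2 is therefore unreadable in size, as the limit of > 100000 nM in this assay, at which 2 of the 2 values shown sit, shows. Compound 3, `CCCCCc1oc2ccccc2c(=O)c1O`, is not yet measured; it differs from compound 2 by pentyl in place of tert-butyl on an aromatic carbon. For the measured compounds named here, no measured step bears on this change, so no direction can be drawn from the data. Compound 3 is expected to give 150000 nM, between 30000 nM and 1000000 nM. This expected result means a step that the limit leaves unreadable from compound 2 to compound 3.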

Compound 3, half-maximal inhibitory concentration: > 100000 nM
Compound 3: only a limit was reported (the forecaster's own chance of this, stated with the estimate: 80%); the middle value is on the limit's open side.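

No size can be read for any step among compound 1, compound 2 and compound 3, because each result is a limit of the assay and not a number: the limit of > 100000 nM in this assay, at which 3 of the 3 values shown sit.

The compounds shown leave open how these three alkyl chains on the shared core rank in this assay.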